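A few compounds are considered here, and "the series" means these few. Any claim that something is new, unique, unknown or untested is made for them only; others in the source may bear on it.

Measured in a physicochemical assay for lipophilicity, using the shake flask method, in phosphate buffer, measured as octanol-water partition, with a stated time of 30 min, at pH 7.4; a higher number here means a more lipophilic compound, a lower number a more polar compound:
- Compound 1 `CN(c1ncco1)c1cnc(NCc2c(F)ccc3c2CCO3)n2cnnc12`: 2.1
- Compound 2 `Cn1nccc1-c1cnc(NCc2c(F)ccc3c2CCO3)c2cn[nH]c(=O)c12`: 2.6
- Compound 3 `O=C1CCCN1c1cnc(NCc2c(F)ccc3c2CCO3)c2cn[nH]c(=O)c12`: 1.8

Compound 1, at 2.1, lies below compound 2, at 2.6, by more than the usual scatter. It cannot be told apart from compound 3, at 1.8.

Compound 4 `COCCC(=O)Nc1cnc(NCc2c(F)ccc3c2CCO3)n2cnnc12` has not yet been measured. It keeps the core of compound 1 and differs in one group, on an aromatic carbon of a six-membered aromatic ring with 2 nitrogen: ((2-methoxyethyl)carbonyl)amino in place of methyl(1,3-oxazol-2-yl)amino on an aromatic carbon. A five-membered aromatic ring leaves, and a chain with a carbonyl and no ring enters.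

Within the data shown here, no measured step starts from compound 1, so the only guide is an indirect one. That guide is a number 0.80 log units lower from compound 2 to compound 3 (beyond the scatter). There, too, a five-membered aromatic ring leaves and a group with a carbonyl enters, although on a different core and with a ring still present in the new group. The parallel is therefore loose, but it points downward in this assay, and a drop of somewhat smaller size seems a reasonable expectation. The expected change is a number 0.60 log units lower from compound 1 to compound 4 (beyond the scatter). For compound 4 the estimated value is 1.5, with an expected range from 1.1 to 1.9.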

Compound 4, distribution coefficient: 1.4
For compound 4 the middle estimate is 0.10 log units above the measured one; the measured number falls inside the stated range.
By their numbers in this assay, from the lowest: compound 4; then compounds 3 and 1 (each within the scatter of the next); then compound 2.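

In this assay, among these compounds, the replacement of methyl(1,3-oxazol-2-yl)amino by ((2-methoxyethyl)carbonyl)amino gives a number 0.70 log units lower from compound 1 to compound 4 (beyond the scatter), the first measured step at this position on this core, and it comes with the same count of 7 heavy atoms in the group that leaves and the group that enters. The direction matches a number 0.80 log units lower from compound 2 to compound 3 (beyond the scatter), which was seen on a different core, so two steps in which a five-membered aromatic ring leaves and a group with a carbonyl enters now point the same way, and no compound shown goes against this. No supporting measurement is available to explain why the number falls with this change.

Among the compounds shown here, the single step changes several things at once: the ring goes, and one hydrogen-bond donor and a carbonyl enter, so the contribution of each remains unresolved. A simple acetylamino group, which lacks the methoxy end of the chain, or a dimethylamino group, which has neither a ring nor the amide hydrogen, would help to separate these features at this position.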